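Bromine Added Beside the Hydroxy Group of Compound 3

The source may hold more compounds than are shown below. What is called first, only, known or untested is meant among the compounds shown, and "the series" means these compounds.

Compound 1, `O=C(Nc1ccc(Sc2nc3ccccc3s2)c(Cl)c1)c1ccccc1O`, gives 64000 nM in an ADME assay on HEK293 cells (Homo sapiens) for cytotoxicity, read by reporter gene assay and resazurin assay, with a stated time of 48 h; a higher number here means that more compound is tolerated, a lower number that less compound is tolerated.
Compound 2, `O=C(Nc1ccc(Sc2nc3ccccc3s2)c(Cl)c1)c1ccccc1`, gives 90000 nM in this assay.
Compound 3, `O=C(Nc1ccc(Sc2nc3ccccc3s2)c(Cl)c1)c1cc(Br)ccc1O`, gives 45000 nM in this assay.

Compound 3 holds the lowest of the three numbers, yet the steps leading to it are small: a 1.4-fold lower number from compound 1 to compound 3 (0.15 log units; within the scatter) and a 2.0-fold lower number from compound 2 to compound 3 (0.30 log units; within the scatter), and the remaining pair shows a 1.4-fold higher number from compound 1 to compound 2 (0.15 log units; within the scatter). All three compounds therefore sit in one band in this assay.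

Compound 4, `O=C(Nc1ccc(Sc2nc3ccccc3s2)c(Cl)c1)c1cc(Br)cc(Br)c1O`, is not yet measured. It differs from compound 3 by bromo in place of hydrogen on an aromatic carbon. Going by the values given here, the one measured step of the same kind, a 1.4-fold lower number from compound 1 to compound 3 (0.15 log units; within the scatter), stayed within the scatter, and the swap of the whole acyl group, a 2.0-fold lower number from compound 2 to compound 3 (0.30 log units; within the scatter), did likewise. On this basis the second bromo is expected to move the number little, if at all, and any shift is expected to point downward, as in a 1.4-fold lower number from compound 1 to compound 3 (0.15 log units; within the scatter). Compound 4 is estimated at 35000 nM, between 15000 nM and 80000 nM, so that the expected step is a 1.3-fold lower number from compound 3 to compound 4 (0.11 log units; within the scatter).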

Compound 4, half-maximal cytotoxic concentration: 76000 nM
For compound 4 the middle estimate is 2.2-fold (0.34 log units) below the measured one; the range from low to high includes it.
By their numbers in this assay, from the lowest: compounds 3, 1, 4 and 2 (each within the scatter of the next).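

Going by these compounds alone, the second bromo, on an aromatic carbon ortho to a hydroxy group and meta to a bromo group, gives a 1.7-fold higher number from compound 3 to compound 4 (0.23 log units; within the scatter) in this assay and so leaves the number within the scatter at a place that carried only hydrogen in the earlier compounds. The complete 3,5-dibromo-2-hydroxyphenyl group also stays within the scatter of both simpler acyl groups, with a 1.2-fold lower number from compound 2 to compound 4 (0.07 log units; within the scatter) and a 1.2-fold higher number from compound 1 to compound 4 (0.07 log units; within the scatter) showing that this band extends to a doubly brominated ring. No measurement shown here accounts for these small steps.

Going by these compounds, it remains open whether an amine or a carboxylic acid at this place would stay within the same band. Every bromo compound shown also carries the hydroxy group, so a bromo-substituted phenyl without that hydroxy group remains untested here.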